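Chloro for Methyl: Expected Cytotoxicity of Compound 3

A few compounds are considered here, and "the series" means these few. Any claim that something is new, unique, unknown or untested is made for them only; others in the source may bear on it.

Compound 1, `COC(=O)c1cc(-c2cccc(NC(=O)c3ccc(/C=C/C(=O)c4ccccc4OC)cc3)c2)on1`: > 40 ug/mL
Compound 2, `COC(=O)c1cc(-c2cccc(NC(=O)c3ccc(/C=C/C(=O)c4ccccc4C)cc3)c2)on1`: > 25 ug/mL

In an ADME assay on Vero cells (Chlorocebus sabaeus) for cytotoxicity, read by MTT assay, with a stated time of 72 h (on this read-out lower numbers stand for higher toxicity in this test and higher numbers for lower toxicity in this test), compound 2 gives > 25 ug/mL, which is a limit of the assay rather than a number. Compound 1 likewise stands at a limit, > 40 ug/mL. The step that the two limits leave unreadable from compound 1 to compound 2 therefore cannot be read from these two values. Compound 3 `COC(=O)c1cc(-c2cccc(NC(=O)c3ccc(/C=C/C(=O)c4ccccc4Cl)cc3)c2)on1` differs from compound 2 by chloro in place of methyl on an aromatic carbon. Among the measured compounds shown here, no measured step speaks to this change, so no shift beyond the usual scatter is expected. Compound 3 is estimated at 40 ug/mL (range 15 ug/mL to 100 ug/mL). The expected step is a step that the limit leaves unreadable from compound 2 to compound 3.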

Compound 3, half-maximal cytotoxic concentration: > 25 ug/mL
Compound 3: no number, only a limit; the forecaster's own chance of this, stated with the estimate: 75%; the middle value is on the limit's open side.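

Among the compounds shown here, compound 3 stands at a limit, > 25 ug/mL, not a number, so no step between it and compound 1 or compound 2 can be read. On these data alone, whether methoxy, methyl or chloro at this aromatic carbon shifts cytotoxicity at all remains open.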